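One Halogen Swap on a Shared Anticonvulsant Core

A few compounds are considered here, and "the series" means these few. Any claim that something is new, unique, unknown or untested is made for them only; others in the source may bear on it.

compound 1 `Fc1ccc(/C=N/NC(=S)Nc2nc3ccc(Cl)cc3s2)cc1` — 30 mg/kg
compound 2 `O=C(Cn1ccc2ccccc21)Nc1nc2ccc(Cl)cc2s1` — 100 mg/kg
compound 3 `CC(C)(C)NCC(=O)Nc1nc2ccc(Cl)cc2s1` — 30 mg/kg

Three compounds built on the core of compound 1 were tested in a functional assay on the whole organism with Mus musculus as the target, in the maximal electroshock model, with a stated time of 0.5 h; on this read-out higher numbers stand for an effect only at larger amounts of compound and lower numbers for an effect already at smaller amounts. Compound 1 gives 30 mg/kg, level with compound 3 at 30 mg/kg, and these two together hold the lowest of the three numbers. Compound 2 at 100 mg/kg stands furthest from compound 1, a gap beyond the usual scatter. Compound 4 `S=C(N/N=C/c1ccccc1Cl)Nc1nc2ccc(Cl)cc2s1` has not yet been measured. It differs from compound 1 in one place: 2-chlorophenyl in place of 4-fluorophenyl on a carbon with a double bond to nitrogen. Among the compounds with values here, no step of this kind between measured compounds is available, so the change is expected to move the number only a little, in neither direction beyond the scatter. For compound 4 the expected value is 30 mg/kg, with a range from 10 mg/kg to 100 mg/kg. The expected step is no change at the digits printed from compound 1 to compound 4 (within the scatter).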

Compound 4, minimum effective dose: 300 mg/kg
Compound 4: middle estimate off by 10-fold (1.00 log units), on the low side; the whole stated range lies below it.
By their numbers in this assay, from the lowest: compounds 1 and 3 (each within the scatter of the next); then compound 2; then compound 4.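

This position is not a silent one: in this assay the swap to 2-chlorophenyl in place of 4-fluorophenyl gives a 10-fold higher number from compound 1 to compound 4 (1.00 log units; beyond the scatter), so the number responds to the choice of ring here. The two groups have matching counts of heavy atoms, hydrogen-bond donors and acceptors, and those counts do not tell them apart. No measurement that explains the step is available. The compounds shown leave open whether the halogen or its place on the ring matters more. 4-Chlorophenyl and 2-fluorophenyl would each change only one of the two, and plain phenyl would show the ring with no halogen.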